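Does a 4-bromophenyl group change tolerance?

The compounds below may be only part of what the source reports. "The series", "measured", "known", "first", "only" and "open" are said of these compounds alone.

Measured in a toxicity assay on HaCaT cells (Homo sapiens) for cytotoxicity, read by CCK-8 assay, with a stated time of 24 h; a lower number here means that less compound is tolerated, a higher number that more compound is tolerated:
Compound 1 `COc1ccccc1Oc1c(N)nc(-c2ccccc2F)nc1Cl`: > 80000 nM (a limit of the assay, not a number)
Compound 2 `COc1ccccc1Oc1c(N)nc(-c2cccc(Cl)c2)nc1Cl`: > 80000 nM (a limit of the assay, not a number)

Compound 2 gives > 80000 nM, which is only a limit. Among the measured compounds shown here, the one measured step, a step that the two limits leave unreadable from compound 1 to compound 2, has no readable size. The closest guide is the limit of > 80000 nM in this assay, at which 2 of the 2 values shown sit. Compound 3 `COc1ccccc1Oc1c(N)nc(-c2ccc(Br)cc2)nc1Cl` carries 4-bromophenyl in place of 3-chlorophenyl on an aromatic carbon. No step beyond the scatter is expected in this assay, so no direction is predicted. The expected step is a number no higher from compound 2 to compound 3 (the limit leaves the size open). Compound 3 is estimated at 80000 nM, with an expected range from 40000 nM to 160000 nM.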

Compound 3, half-maximal cytotoxic concentration: 58600 nM
Beside the measured number, compound 3's estimate is 1.4-fold (0.14 log units) above it, within the range that was stated.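

In this assay, compound 3 is the first compound shown to give a measured number rather than a limit, so this position can yield a readable value. The readable steps are an at least 1.3-fold lower number from compound 2 to compound 3 (0.13 log units; that floor lies within the scatter) and an at least 1.3-fold lower number from compound 1 to compound 3 (0.13 log units; that floor lies within the scatter), so neither shows a change beyond the usual scatter. The step from compound 1 to compound 2 cannot be read, and most of the values remain limits: the limit of > 80000 nM in this assay, at which 2 of the 3 values shown sit.

On these data alone, whether the halogen or its place on the phenyl ring matters more stays open, since both differ in compound 3. As far as these compounds go, how an amine or a carboxylic acid on that ring would read also stays open.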